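The compounds below may be only part of what the source reports. "The series", "measured", "known", "first", "only" and "open" are said of these compounds alone.

Of the compounds shown here, two have so far been measured in a functional assay on HepG2 cells (Homo sapiens) for cytotoxicity, read by XTT assay, with a stated time of 72 h; on this read-out lower numbers stand for stronger inhibition and higher numbers for weaker inhibition. Compound 1, `CCOC(=O)c1[se]c(N(/N=C/c2ccc(Cl)cc2)C(C)=O)nc1C`, gives 55200 nM in this assay. Compound 2, `Cc1c[se]c(NNC(=O)c2ccccc2)n1`, is reported in this assay only as a limit, > 89200 nM, which is the limit of > 89200 nM in this assay, at which 1 of the 2 values shown sits. Compound 2 therefore stands at the ceiling of what this assay records and has no number of its own. Compound 3, `O=C(NNc1nc(-c2ccccc2)c[se]1)c1ccccc1`, has not yet been measured in this assay. It differs from compound 2 in one place: phenyl in place of methyl on an aromatic carbon. For the measured compounds named here, no measured pair in this set shows what such a change does in this assay, so there is no basis for expecting a large step in either direction. Compound 3 is expected to give about 80000 nM in this assay, with a likely range from 30000 nM to 150000 nM. The step of an at least 1.1-fold lower number from compound 2 to compound 3 (0.04 log units; that floor lies within the scatter) is expected to be small and not beyond the scatter.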

Compound 3, half-maximal inhibitory concentration: > 73000 nM
Compound 3 was reported as a limit (the forecaster's own chance of this, stated with the estimate: 60%); the middle value does not contradict the limit.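

For the compounds shown here, compound 2 and compound 3 are both reported in this assay only as limits, and no step between them can be read. The compounds shown leave open what phenyl in place of methyl on an aromatic carbon does to the half-maximal inhibitory concentration.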